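Trading Dimethylamino for Bromo: Compound 1 to Compound 3

The source may hold more compounds than are shown below. What is called first, only, known or untested is meant among the compounds shown, and "the series" means these compounds.

Two compounds have so far been measured in a functional assay on ECa-109 cells (Homo sapiens) for antiproliferative activity, read by MTT assay, with a stated time of 72 h; on this read-out lower numbers stand for stronger inhibition and higher numbers for weaker inhibition:
- compound 1 `CCCSc1nc(N/N=C/c2ccc(N(C)C)cc2)c2nnn(Cc3ccccc3)c2n1` gives 20000 nM
- compound 2 `C#CCSc1nc(N/N=C/c2c(O)ccc3ccccc23)c2nnn(Cc3ccccc3)c2n1` gives 6520 nM

Compound 1 therefore stands at the highest number of the two, and compound 2 sits a good way lower, a gap that is beyond the usual scatter. The two differ in more than one place, so nothing can be read from them about any single change.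

Compound 3 `CCCSc1nc(N/N=C/c2ccc(Br)cc2)c2nnn(Cc3ccccc3)c2n1` is the next compound to be tested. It differs from compound 1 in one place: bromo in place of dimethylamino on an aromatic carbon. Among the measured compounds shown here, no measured pair isolates this change, so there is no direct guide to its effect. The expectation is a step of a 1.3-fold lower number from compound 1 to compound 3 (0.12 log units; within the scatter), small and within the scatter rather than a clear gain or loss. Compound 3 is thus estimated at 15000 nM, with a plausible range from 5000 nM to 45000 nM.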

Compound 3, half-maximal inhibitory concentration: > 64000 nM
Compound 3 was reported as a limit; the forecaster's own chance of this, stated with the estimate: 15%; at least 4.2-fold (0.63 log units) between middle value and limit.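

Among the compounds shown here, replacing dimethylamino with bromo on this aromatic carbon, para to a large group, gives an at least 3.2-fold higher number from compound 1 to compound 3 (0.50 log units; beyond the scatter), and this is the first step in this assay that isolates a single change. Compound 3 is reported only as a limit, not as a number: the limit of > 64000 nM in this assay, at which 1 of the 3 values shown sits. With the rest of the molecule unchanged, this one swap moves the read-out towards weaker inhibition by more than the scatter, so the group at this position matters for the result.

This single pair cannot show whether the shift comes from removing dimethylamino or from introducing bromo, and the limit leaves the full size of the step unknown. A methoxy group, a primary amine or a plain hydrogen at the same place would help separate those two possibilities.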